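The compounds below may be only part of what the source reports. "The series", "measured", "known", "first", "only" and "open" are said of these compounds alone.

Among the compounds with values here, in a functional assay on SF-268 cells (Homo sapiens) for inhibition (a higher number here means a weaker inhibitor of growth, a lower number a stronger inhibitor of growth), compound 2 `COc1ccc(-n2cnnc2-c2cc(OC)c(OC)c(OC)c2)cc1O` gives 257 nM, the lower of the two numbers measured so far, while compound 1 `COc1ccc(-n2cnnc2-c2cc(OC)c(OC)c(OC)c2)cc1` gives 5890 nM. Compound 3 `COc1ccc(-n2cnnc2-c2cc(OC)c(OC)c(OC)c2)cc1F` carries fluoro in place of hydroxy on an aromatic carbon. Within the data shown here, one measured step bears on this change, the large 23-fold lower number from compound 1 to compound 2 (1.36 log units; beyond the scatter), which came with hydroxy in place of hydrogen. Among the measured compounds shown here, no measurement yet shows how fluoro behaves, but losing the hydroxy is expected to give back much of that step, towards a higher number. The expected change is a 5.8-fold higher number from compound 2 to compound 3 (0.77 log units; beyond the scatter). Compound 3 is estimated at 1500 nM, with an expected range of 350 nM to 6000 nM.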

Compound 3, concentration for 50% growth inhibition: 9330 nM
The estimate for compound 3 lay 6.2-fold (0.79 log units) below the measured number; measured number above the stated range.
By their numbers in this assay, from the lowest: compound 2; then compounds 1 and 3 (each within the scatter of the next).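

In this assay fluoro in place of hydroxy brings a 36-fold higher number from compound 2 to compound 3 (1.56 log units; beyond the scatter) and so loses the whole gain that the hydroxy gave at this position. Fluoro in place of hydrogen brings only a 1.6-fold higher number from compound 1 to compound 3 (0.20 log units; within the scatter) so compound 1 and compound 3 cannot be told apart, and at this position fluoro does not stand in for the hydroxy. No measurement here explains why the two groups differ.

Going by these compounds, it remains open whether any group other than the hydroxy can match it. An amine or a hydroxymethyl group at the same position would test this.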